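The source may report more compounds than this note shows. Statements on the series, on what has been measured and on what is new or still open speak of the compounds shown alone.

In a functional assay on KB cells (Homo sapiens) for antiproliferative activity, read by sulforhodamine B assay, with a stated time of 3 days (a lower number here means a stronger inhibitor of growth, a higher number a weaker inhibitor of growth), compound 1 `COc1ccc(NC(=O)c2cccc(Nc3ncc(F)c(Nc4ccc(F)cc4)n3)c2)cc1` gives > 10000 nM, which is a limit and not a number. Compound 2 `CN(C)c1ccc(C(=O)Nc2cccc(Nc3ncc(F)c(Nc4ccc(F)cc4)n3)c2)cc1` gives > 10000 nM, again only a limit. Compound 2 therefore stands at the limit of > 10000 nM in this assay, at which 2 of the 2 values shown sit. Compound 3 `COCC(=O)Nc1cccc(Nc2ncc(F)c(Nc3ccc(F)cc3)n2)c1` carries methoxymethyl in place of 4-(dimethylamino)phenyl on a carbonyl carbon. Within the data shown here, no measured step covers this change. The step of an at least 1.4-fold lower number from compound 2 to compound 3 (0.15 log units; that floor lies within the scatter) is expected to be modest, towards stronger growth inhibition in this assay, and a further limit remains quite possible. For compound 3 the estimated value is 7000 nM, with an expected range from 1000 nM to 20000 nM.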

Compound 3, concentration for 50% growth inhibition: 6250 nM
The estimate for compound 3 lay 1.1-fold (0.05 log units) above the measured number; measured number inside the range.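

In this assay, among these compounds, compound 3 gives 6250 nM, the first number rather than a limit. The steps read an at least 1.6-fold lower number from compound 2 to compound 3 (0.20 log units; that floor lies within the scatter) and an at least 1.6-fold lower number from compound 1 to compound 3 (0.20 log units; that floor lies within the scatter); both floors lie within the scatter, so neither change is shown to be a real gain, and the true size of each stays unknown. The other two compounds remain limits: the limit of > 10000 nM in this assay, at which 2 of the 3 values shown sit.

Open, as far as these compounds go, is whether the number at this carbonyl carbon follows the loss of the aromatic ring or the ether oxygen of methoxymethyl. An ethyl or a longer ether chain at that place would separate the two.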